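Replacing chloro with methoxy on a nitrothiazole salicylamide core

The source may report more compounds than this note shows. Statements on the series, on what has been measured and on what is new or still open speak of the compounds shown alone.

Measured so far:
compound 1 `O=C(Nc1ncc([N+](=O)[O-])s1)c1cc(Cl)ccc1O` gives 100%
compound 2 `O=C(Nc1ncc([N+](=O)[O-])s1)c1cc(Cl)cc(Cl)c1O` gives 100%

Of the compounds shown here, two on the shared core have been tested in an ADME assay on HEK-293T cells (Homo sapiens) for cytotoxicity, read by MTT assay, tested at 25 uM; a higher number here means a weaker effect of the compound at the concentration tested, a lower number a stronger effect. Compound 1 is level with compound 2 at the digits shown, and the single step between them, no change at the digits printed from compound 1 to compound 2 (within the scatter), introduced a chloro in place of hydrogen on an aromatic carbon without moving the read-out beyond the scatter. Neither compound therefore shows an effect in this assay at the concentration used.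

Compound 3 `COc1ccc(O)c(C(=O)Nc2ncc([N+](=O)[O-])s2)c1` has not yet been measured. It differs from compound 1 as follows: methoxy in place of chloro on an aromatic carbon. Among the compounds with values here, the only measured step bearing on this change is the one from compound 1 to compound 2, which altered the same aromatic ring and left the read-out unchanged. With both measured values at the top of the scale, the step expected here, no change at the digits printed from compound 1 to compound 3 (within the scatter), is none beyond the scatter. Compound 3 is accordingly estimated to give 100% in this assay, within a range from 85% to 105%.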

Compound 3, a percentage reported as activity, at one concentration (the size of the read-out at that concentration, not a potency): 100%
For compound 3 middle estimate and measured number coincide at the digits printed; the range from low to high includes it.
By their numbers in this assay, from the lowest: compounds 1, 2 and 3 (each within the scatter of the next).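

Replacing the chloro group of compound 1 with methoxy, on an aromatic carbon para to a hydroxy group, gives no change at the digits printed from compound 1 to compound 3 (within the scatter) in this assay. The earlier step had added a chloro group while keeping the one at this place, whereas this step changes the group at this place itself, so the read-out now holds with either chloro or methoxy there, although methoxy brings one more heavy atom and a hydrogen-bond acceptor. Nothing measured here explains why the read-out stays the same, and no supporting evidence bears on this result. 

The compounds shown leave open whether this place would give the same read-out in this assay with an amine, a carboxylic acid or a longer chain such as butoxy, since chloro and methoxy are the only groups seen there. They also leave open whether the core would keep this read-out with the hydroxy group or the nitro group replaced, since all three compounds carry both.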